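The source may report more compounds than this note shows. Statements on the series, on what has been measured and on what is new or still open speak of the compounds shown alone.

Measured in an ADME assay on BJ cells (Homo sapiens) for cytotoxicity, with a stated time of 72 h; on this read-out lower numbers stand for an effect already at smaller amounts and higher numbers for an effect only at larger amounts of compound:
compound 1 `COc1cccc(-c2nc3c(c(C)nn3-c3ccccc3)c(-c3ccccc3O)c2C#N)c1`: > 23000 nM
compound 2 `CCc1ccc(-c2nc3c(c(C)nn3-c3ccccc3)c(-c3ccccc3OC)c2C#N)cc1`: > 20000 nM
compound 3 `C#Cc1ccccc1-c1c(C#N)c(-c2ccc(CC)cc2)nc2c1c(C)nn2-c1ccccc1`: > 20000 nM

Each of these readings is a limit of the assay and not a number. Compound 1 sits at the limit of > 23000 nM in this assay, at which 1 of the 3 values shown sits. Compound 2 and compound 3 sit at the limit of > 20000 nM in this assay, at which 2 of the 3 values shown sit. Within the data shown here, no cytotoxic concentration has therefore been read for any compound so far.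

Compound 4 `Cc1nn(-c2ccccc2)c2nc(-c3ccc(C(F)(F)F)cc3)c(C#N)c(-c3ccccc3O)c12` keeps the 2-hydroxyphenyl group of compound 1. It carries 4-(trifluoromethyl)phenyl in place of 3-methoxyphenyl on an aromatic carbon, next to the ring nitrogen and ortho to a cyano group: 4-(trifluoromethyl)phenyl in place of 3-methoxyphenyl on an aromatic carbon.

Among the measured compounds shown here, the only measured step is a step that the two limits leave unreadable from compound 2 to compound 3. That step concerns a different substituent and has no readable size, so it offers no size to carry over to this change. The expectation rests mainly on compound 1, whose limit is > 23000 nM. No step beyond the scatter is expected in this assay, and another limit is the most likely report for compound 4.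

The expected step is an at least 1.1-fold lower number from compound 1 to compound 4 (0.06 log units; that floor lies within the scatter).

For compound 4 the estimate is 20000 nM, with an expected range of 8000 nM to 40000 nM.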

Compound 4, half-maximal effective concentration: 22900 nM
Beside the measured number, compound 4's estimate is 1.1-fold (0.06 log units) below it; low and high end bracket the measured number.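

In this assay, among these compounds, compound 4 gives 22900 nM, the first reading that is a number and not a limit. Compound 1, which differs from compound 4 only in the group on the aromatic carbon next to the ring nitrogen and ortho to a cyano group, stays a limit and not a number: the limit of > 23000 nM in this assay, at which 1 of the 4 values shown sits. With the 2-hydroxyphenyl group kept, 4-(trifluoromethyl)phenyl in place of 3-methoxyphenyl at this place gives a number no higher from compound 1 to compound 4 (the limit leaves the size open), so a cytotoxic concentration can be read for this substitution, but the change cannot be given a size.

The compounds shown do not separate the contribution of the trifluoromethyl group from that of losing the methoxy group, nor do they show whether the 2-hydroxyphenyl group is needed for a number to be read with 4-(trifluoromethyl)phenyl. On these data alone, how a phenyl group carrying an amine or a carboxylic acid would read at this place also stays open.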